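Shifting a Ring Nitrogen: From Compound 2 to Compound 3

This account rests on a few compounds, and the source may have more. Where it says the series, first, only, none or still open, it means among the compounds named here.

Of the compounds shown here, two have been measured in an ADME assay on Vero cells (Chlorocebus sabaeus) for cytotoxicity, read by MTT assay; a higher number here means a weaker inhibitor, a lower number a stronger inhibitor. Compound 1 `C=CCOc1cc(OC)c(C(=O)/C=C/c2ccc(C(F)(F)F)cc2)c(OCC=C)c1` gives 7200 nM, and compound 2 `C=CCOc1cc(OC)c(C(=O)/C=C/c2ccccn2)c(OCC=C)c1` gives 2800 nM. Compound 2 stands at the lowest number of the two measured, separated from compound 1 by the step of a 2.6-fold lower number from compound 1 to compound 2 (0.41 log units; beyond the scatter). Compound 3 `C=CCOc1cc(OC)c(C(=O)/C=C/c2ccncc2)c(OCC=C)c1` has not yet been measured. It differs from compound 2 in one place: pyridin-4-yl in place of pyridin-2-yl on a double-bonded chain carbon bound to a double-bonded chain carbon. Within the data shown here, the single measured step replaces one aromatic ring with a different one, whereas the change to compound 3 exchanges pyridin-2-yl for pyridin-4-yl, so that step bears on the new one only loosely. Lacking a closer precedent, the step expected from compound 2 to compound 3 is a 1.1-fold higher number from compound 2 to compound 3 (0.03 log units; within the scatter), that is, no change beyond the scatter. Compound 3 is therefore estimated at 3000 nM in this assay, with a likely range from 1200 nM to 8000 nM.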

Compound 3, half-maximal inhibitory concentration: 2800 nM
The estimate for compound 3 lay 1.1-fold (0.03 log units) above the measured number; the measured number falls inside the stated range.
By their numbers in this assay, from the lowest: compounds 2 and 3 (each within the scatter of the next); then compound 1.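

In this assay, exchanging pyridin-2-yl for pyridin-4-yl on this double-bonded chain carbon gives no change at the digits printed from compound 2 to compound 3 (within the scatter), so among these compounds the place where the ring joins the chain, relative to its nitrogen, leaves no mark on the number. Replacing 4-(trifluoromethyl)phenyl with pyridin-4-yl gives a 2.6-fold lower number from compound 1 to compound 3 (0.41 log units; beyond the scatter) and replacing it with pyridin-2-yl gave a 2.6-fold lower number from compound 1 to compound 2 (0.41 log units; beyond the scatter), so the earlier step now holds for two pyridine groups rather than one. Nothing available explains why these two groups give matching numbers.

Still open, as far as these compounds go, is whether pyridin-3-yl would give a number in line with compound 2 and compound 3. Also open, from the compounds shown here alone, is how a phenyl ring carrying an amine or a carboxylic acid in place of trifluoromethyl would compare with compound 1.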